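A few compounds are considered here, and "the series" means these few. Any claim that something is new, unique, unknown or untested is made for them only; others in the source may bear on it.

In a physicochemical assay for lipophilicity, at pH 7.4 (on this read-out lower numbers stand for lower lipophilicity and higher numbers for higher lipophilicity), compound 3 `CO[C@H](C[C@H](CCN1CCCC(CO)C1)C(=O)NO)c1ccc(F)cc1` gives < 3, which is a limit and not a number. Compound 1 `COc1ccc(CNCCCC[C@@H](Nc2cc(C)c(F)c(C)c2)C(=O)NO)cc1` gives < 3, also a limit. Compound 2 `Cc1cc(N[C@H](CCCCNCc2ccc(C(C)(C)C)cc2)C(=O)NO)cc(C)c1F` gives < 3, again a limit. All three compounds therefore rest on one mark: the limit of < 3 in this assay, at which 3 of the 3 values shown sit. Where compound 3 truly stands remains unknown.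

Compound 4 `CO[C@H](C[C@H](CCN1CCCC(Cc2ccc(F)cc2)C1)C(=O)NO)c1ccc(F)cc1` differs from compound 3 in one place: 4-fluorophenyl in place of hydroxy on a saturated chain carbon bound to a saturated ring carbon. In words, 4-fluorophenyl stands in place of hydroxy on a saturated chain carbon bound to a saturated ring carbon, or, cut one bond further out, hydroxymethyl becomes 4-fluorobenzyl.

Going by the values given here, the only measured single change, a step that the two limits leave unreadable from compound 1 to compound 2, is tert-butyl in place of methoxy on an aromatic carbon, so it offers no size to carry over. The expectation therefore rests on the structural change alone, and it points to a higher number in this assay. The expected step is a step that the limit leaves unreadable from compound 3 to compound 4. For compound 4 the estimate is 2.6, with an expected range of 1.6 to 3.5.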

Compound 4, distribution coefficient: < 3
Compound 4 was reported as a limit; the forecaster's own chance of this, stated with the estimate: 65%; the middle value is on the limit's open side.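

Going by these compounds alone, compound 3 and compound 4 are each reported only as a limit and not as a number, so no step between them can be read. What stays open is where any of the four compounds truly stands in this assay, and whether changing hydroxymethyl to 4-fluorobenzyl moves the number at all: the limit of < 3 in this assay, at which 4 of the 4 values shown sit.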